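Notes on pyridin-3-yl in place of 2-chlorophenyl

A few compounds are considered here, and "the series" means these few. Any claim that something is new, unique, unknown or untested is made for them only; others in the source may bear on it.

In a functional assay on U-937 cells (Homo sapiens) for antiproliferative activity, read by MTT assay, with a stated time of 72 h (on this read-out lower numbers stand for stronger inhibition and higher numbers for weaker inhibition), compound 1 `Cc1ccc(-c2noc(CCCCCCC(=O)NO)n2)cc1` gives 1360 nM, compound 2 `COc1ccc(-c2noc(CCCCCCC(=O)NO)n2)cc1` gives 3650 nM and compound 3 `O=C(CCCCCCc1nc(-c2ccccc2Cl)no1)NO` gives 750 nM. Compound 3 and compound 1 lie within the scatter of each other, and both numbers are clearly lower than that of compound 2.

The next structure is compound 4 `O=C(CCCCCCc1nc(-c2cccnc2)no1)NO`, where the change is pyridin-3-yl in place of 2-chlorophenyl on an aromatic carbon. The new group sits on the same aromatic carbon, between two ring nitrogen atoms.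

Going by the values given here, two measured steps bear on this. Swapping the whole aryl group gave a 1.8-fold lower number from compound 1 to compound 3 (0.26 log units; within the scatter), and exchanging only its substituent gave a 2.7-fold higher number from compound 1 to compound 2 (0.43 log units; beyond the scatter). Among the compounds with values here, both are small, so no large jump is expected, but no measured compound has a ring nitrogen in this group, which leaves the direction uncertain. With compound 3 at 750 nM already at the low end of the numbers seen, a modest rise is the likelier outcome, and the expected step is a 2.4-fold higher number from compound 3 to compound 4 (0.38 log units; beyond the scatter). In this assay, compound 4 is estimated at 1800 nM, with an expected range from 600 nM to 5000 nM.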

Compound 4, half-maximal inhibitory concentration: 350 nM
For compound 4 the middle estimate is 5.1-fold (0.71 log units) above the measured one; measured number outside the range, below it.
By their numbers in this assay, from the lowest: compound 4; then compounds 3 and 1 (each within the scatter of the next); then compound 2.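

In this assay, a ring nitrogen is tolerated in the aryl group on this aromatic carbon, between two ring nitrogen atoms, and pyridin-3-yl gives a 2.1-fold lower number from compound 3 to compound 4 (0.33 log units; beyond the scatter). Compound 3 could not be separated from compound 1, with a 1.8-fold lower number from compound 1 to compound 3 (0.26 log units; within the scatter), whereas pyridin-3-yl separates clearly from 4-methylphenyl, with a 3.9-fold lower number from compound 1 to compound 4 (0.59 log units; beyond the scatter). The entering group brings a hydrogen-bond acceptor absent from 2-chlorophenyl, but no measurement here explains the lower numbers.

The compounds shown leave open whether the place of the ring nitrogen matters, as pyridin-2-yl or pyridin-4-yl would show, and whether pyrimidin-5-yl would lower the number further. Also open, on these data alone, is whether the lower number would hold with a methyl group or an amine on the pyridine ring.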